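Dropping a Trifluoromethyl from an Amide-Linked Cell Toxicity Probe

The source may report more compounds than this note shows. Statements on the series, on what has been measured and on what is new or still open speak of the compounds shown alone.

Compound 1, `COc1cc(-c2nn(-c3cccc(NC(=O)c4cccc(C(F)(F)F)c4)c3)cc2-c2ccncc2)ccc1Cl`: > 50000 nM
Compound 2, `O=C(Nc1cccc(-n2cc(-c3ccncc3)c(-c3ccc(Cl)c(O)c3)n2)c1)Nc1cc(C(F)(F)F)cc(C(F)(F)F)c1`: 4860 nM

Of the compounds shown here, two have been tested in a functional assay on NCI-H460 cells (Homo sapiens) for inhibition, read by sulforhodamine B assay, with a stated time of 48 h; on this read-out higher numbers stand for lower toxicity in this test and lower numbers for higher toxicity in this test. Compound 1 gives > 50000 nM; this is a limit of the assay and not a number. Compound 2 gives 4860 nM. Compound 1 therefore stands at the limit of > 50000 nM in this assay, at which 1 of the 2 values shown sits, the point where the test stops reporting a value.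

The compound now in question is compound 3 `COc1cc(-c2nn(-c3cccc(NC(=O)c4ccccc4)c3)cc2-c2ccncc2)ccc1Cl`, which differs from compound 1 in one respect only: hydrogen in place of trifluoromethyl on an aromatic carbon. Going by the values given here, no pair of measured compounds that differ in a single place is available, so the size of this step cannot be read from data and has to be judged. Because compound 1 already sits at the limit of > 50000 nM in this assay, at which 1 of the 2 values shown sits, a number for compound 3 may again not be reached, and the direction of any shift is open. The expected step is a step that the limit leaves unreadable from compound 1 to compound 3, nothing beyond the usual scatter. Compound 3 is accordingly expected at 60000 nM, within a range from 20000 nM to 200000 nM.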

Compound 3, concentration lethal to 50% of the cells: > 100000 nM
Compound 3 gave a limit, no number (the forecaster's own chance of this, stated with the estimate: 75%); middle value at least 1.6-fold (0.22 log units) away from the limit.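

In this assay compound 3 gives > 100000 nM, a limit of the test and not a number. Going by these compounds alone, compound 1 also stands at a limit, and no step between compound 1 and compound 3 can be read. The compounds shown leave open whether hydrogen in place of trifluoromethyl changes this read-out at all.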